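The source may hold more compounds than are shown below. What is called first, only, known or untested is meant among the compounds shown, and "the series" means these compounds.

Compound 1 `COc1cc(-c2ccnc3cc(-c4c[nH]c5ccccc45)nn23)cc(OC)c1OC` is the stronger of the two measured compounds in a functional assay on A549 cells (Homo sapiens) for inhibition, read by CCK-8 assay, with a stated time of 48 h; a lower number here means a stronger inhibitor, a higher number a weaker inhibitor: compound 1 gives 29 nM, the lowest of the two numbers. Compound 2 `COc1cc(-c2ccnc3cc(-c4ccc(N(C)C)cc4)nn23)cc(OC)c1OC` carries 4-(dimethylamino)phenyl in place of 1H-indol-3-yl on an aromatic carbon, and in this assay compound 2 gives 1100 nM. Within the data shown here, that single swap is a 38-fold higher number from compound 1 to compound 2 (1.58 log units; beyond the scatter), so the indole ring system appears to matter here, though only this one pair shows it.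

Compound 3 `COc1cc(-c2ccnc3cc(-c4cn(C(=O)OC(C)(C)C)c5ccccc45)nn23)cc(OC)c1OC` keeps the indole but differs from compound 1 by tert-butoxycarbonyl in place of hydrogen on an aromatic nitrogen. Among the measured compounds shown here, no measured step touches this aromatic nitrogen. For the measured compounds named here, the one available step, a 38-fold higher number from compound 1 to compound 2 (1.58 log units; beyond the scatter), replaces the whole ring system rather than capping its nitrogen with a large group, so it bears on compound 3 only indirectly and marks roughly how much could be lost when the indole is disturbed. Some loss of inhibition therefore seems likely, but a smaller one. Compound 3 is expected to give about 120 nM, within a range from 30 nM to 500 nM. For compound 3 this estimate means an expected 4.1-fold higher number from compound 1 to compound 3 (0.62 log units; beyond the scatter).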

Compound 3, half-maximal inhibitory concentration: 2070 nM
The estimate for compound 3 lay 17-fold (1.24 log units) below the measured number; measured number outside the range, above it.
By their numbers in this assay, from the lowest: compound 1; then compounds 2 and 3 (each within the scatter of the next).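

In this assay, tert-butoxycarbonyl in place of hydrogen on the aromatic nitrogen gives a 71-fold higher number from compound 1 to compound 3 (1.85 log units; beyond the scatter) and leaves the rest of the molecule unchanged. The earlier step exchanged the whole indole ring system, so it could not show whether this nitrogen itself matters; this step shows that keeping the indole is not enough to preserve the low number of compound 1, and that a change at this single atom can by itself produce a large step. No measurement shown here gives a reason for this step.

The change does two things at once, removing the hydrogen from the nitrogen and adding a group of 7 heavy atoms, and these compounds cannot tell which of the two accounts for the higher number. A methyl group or an acetyl group on the same aromatic nitrogen would help to separate the two, by showing whether replacing the hydrogen with a much smaller group also gives a large step.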